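Ethyl on the amine nitrogen of compound 3

The source may report more compounds than this note shows. Statements on the series, on what has been measured and on what is new or still open speak of the compounds shown alone.

compound 1 `COc1ccc(C(=O)c2ccc3c(c2)C=CC(C)(C)O3)c(NC(=O)CN)c1` gives 680 nM
compound 2 `C=C(c1ccc(OC)cc1NC(=O)CO)c1ccc(OC)c2c1C=CC(C)(C)O2` gives 590 nM
compound 3 `C=C(c1ccc2c(c1)C=CC(C)(C)O2)c1ccc(OC)cc1NC(=O)CN` gives 420 nM

These three values come from a functional assay on MCF7 cells (Homo sapiens) for antiproliferative activity, read by MTT assay, with a stated time of 48 h (a lower number here means a stronger inhibitor, a higher number a weaker inhibitor), and they sit close together. Compound 3 (420 nM) lies within the usual scatter of both compound 1 and compound 2, so the numbers do not set it apart from either and support no ranking of the three.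

Compound 4 `C=C(c1ccc2c(c1)C=CC(C)(C)O2)c1ccc(OC)cc1NC(=O)CNCC` has not yet been measured. It arises from compound 3 through a single change (ethyl in place of hydrogen on an amine nitrogen) that puts ethyl in place of hydrogen on an amine nitrogen. Among the compounds with values here, no measured pair in this small set isolates such a change, so there is no direct precedent to borrow. The best anchor is compound 3 at 420 nM in this series of closely spaced values. In this assay a small drift toward a higher number is expected, with nothing beyond the scatter: the estimated change is a 1.4-fold higher number from compound 3 to compound 4 (0.15 log units; within the scatter) in this reading. For compound 4 the expected value is 600 nM with an estimated range from 220 nM to 1600 nM when it is tested.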

Compound 4, half-maximal inhibitory concentration: 3370 nM
Beside the measured number, compound 4's estimate is 5.6-fold (0.75 log units) below it; measured number above the stated range.
By their numbers in this assay, from the lowest: compounds 3, 2 and 1 (each within the scatter of the next); then compound 4.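

In this assay, within the data shown here, ethyl in place of hydrogen on the amine nitrogen gives an 8.0-fold higher number from compound 3 to compound 4 (0.90 log units; beyond the scatter) and is the only change here that can be read in one place. The earlier compounds shown here differ from one another in more than one place and their values sit within the scatter, so they could not show whether this position responds to any single change. This step shows that it does: on an amine nitrogen whose other neighbour is a saturated chain carbon, swapping hydrogen for ethyl, with its 2 heavy atoms, carries the number beyond the scatter in the weaker direction, though the compounds offer no measurement that accounts for this.

As far as these compounds go, whether a smaller methyl, a longer propyl chain, a dimethylamino or diethylamino end, or a closed ring such as pyrrolidine would stay near compound 3 or move toward compound 4 remains open, so one step gives no trend with size. From the compounds shown here alone, it is also open whether ethyl on the same nitrogen of compound 1, which carries a carbonyl in place of the shared alkene, would give a comparable step.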